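Acylguanidine series: piperidinyl for methoxy on the sulfonyl-bearing ring

The source may hold more compounds than are shown below. What is called first, only, known or untested is meant among the compounds shown, and "the series" means these compounds.

Measured so far:
compound 1 `COc1cc(Cl)c(C(=O)N=C(N)N)cc1S(C)(=O)=O` — 40 nM
compound 2 `Cc1cc(N2CCCCC2)c(S(C)(=O)=O)cc1C(=O)N=C(N)N` — 21 nM
compound 3 `COc1ccc(C(=O)N=C(N)N)cc1S(C)(=O)=O` — 270 nM

In a functional assay for inhibition of sodium/hydrogen exchanger (Oryctolagus cuniculus) (on this read-out lower numbers stand for stronger inhibition and higher numbers for weaker inhibition), compound 3 gives the highest of the three numbers; the nearest is compound 1, and the step of a 6.8-fold higher number from compound 1 to compound 3 (0.83 log units; beyond the scatter) sets them apart, hydrogen in place of chloro on an aromatic carbon. For the measured compounds named here, compound 2 stands further off still, and no single-point step connects it to compound 3, since compound 2 carries both a methyl and a piperidin-1-yl group that compound 3 lacks.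

Compound 4 `CS(=O)(=O)c1cc(C(=O)N=C(N)N)ccc1N1CCCCC1` is not yet measured. The change from compound 3 is piperidin-1-yl in place of methoxy on an aromatic carbon, that is, piperidin-1-yl in place of methoxy, ortho to a methylsulfonyl group. Going by the values given here, no measured step covers this exact exchange. Among the compounds with values here, the one step known, from compound 1 to compound 3, concerns a different position and is modest. The values of compound 2 and compound 3 show that the piperidin-1-yl-bearing compound sits well below the methoxy-bearing one, though a methyl also differs between them.

For compound 4 a lower number than compound 3 is therefore expected, a step of about a 4.5-fold lower number from compound 3 to compound 4 (0.65 log units; beyond the scatter) in this assay, and the estimate is 60 nM with a range from 20 nM to 200 nM.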

Compound 4, half-maximal inhibitory concentration: 130 nM
Compound 4: middle estimate off by 2.2-fold (0.34 log units), on the low side; measured number inside the range.
By their numbers in this assay, from the lowest: compounds 2 and 1 (each within the scatter of the next); then compound 4; then compound 3.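

Notes on the position ortho to a methylsulfonyl group: in this assay piperidin-1-yl in place of methoxy, read alone for the first time, gives a 2.1-fold lower number from compound 3 to compound 4 (0.32 log units; beyond the scatter), so this place accepts a group of 6 heavy atoms in place of one of 2 and the number still falls modestly. The methyl can now also be read on its own, with a 6.2-fold higher number from compound 2 to compound 4 (0.79 log units; beyond the scatter) as hydrogen replaces it on an aromatic carbon, and of these two single changes the loss of the methyl is the larger, so the piperidin-1-yl exchange alone does not carry the low number of compound 2. Nothing at hand bears on the reason for either step.

The compounds shown leave open whether the six-membered ring itself matters at this place, which a dimethylamino group, a pyrrolidin-1-yl ring or a morpholin-4-yl ring would test against compound 4. They also leave open whether the chloro of compound 1 would lower the number on the piperidin-1-yl compounds as it does on the methoxy compound, and whether an ethyl group in place of the methyl of compound 2 would keep that compound's value.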